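A Methyl Group Tried on Two Different Cores

This account rests on a few compounds, and the source may have more. Where it says the series, first, only, none or still open, it means among the compounds named here.

Compound 1 `COc1cc(CC(O)(COCc2ccccc2)COCc2ccccc2)nc(OC)n1` was tested in a functional assay on HeLa cells (Homo sapiens) for antiproliferative activity, read by MTT assay, with a stated time of 72 h; on this read-out higher numbers stand for weaker inhibition and lower numbers for stronger inhibition. In this assay compound 1 gives only a limit, > 100000 nM. Compound 2 `COc1nc(CC(O)(COCc2ccccc2)COCc2ccccc2)c(C)c(OC)n1` carries methyl in place of hydrogen on an aromatic carbon, and in this assay compound 2 gives 3700 nM, a step of an at least 27-fold lower number from compound 1 to compound 2 (1.43 log units; beyond the scatter). Compound 3 `C[Si](C)(C)CCOCn1c(CC(O)COCc2ccccc2)cc(=O)[nH]c1=O` rests on another core; the difference between the two cores is not broken down here. In this assay compound 3 also gives only a limit, > 100000 nM. This is the limit of > 100000 nM in this assay, at which 2 of the 3 values shown sit. Compound 4 `Cc1c(CC(O)COCc2ccccc2)n(COCC[Si](C)(C)C)c(=O)[nH]c1=O` is not yet measured; it carries methyl in place of hydrogen on an aromatic carbon, the same kind of change as in compound 2, though here the methyl sits ortho to a group of 1 heavy atom, meta to a group of 8 heavy atoms and para to a group of 1 heavy atom rather than ortho and para to a methoxy group. Since compound 3 shows only a limit, the expected step is uncertain; one estimates an at least 3.3-fold lower number from compound 3 to compound 4 (0.52 log units; beyond the scatter), resting on an at least 27-fold lower number from compound 1 to compound 2 (1.43 log units; beyond the scatter). Compound 4 is expected to give 30000 nM, likely from 5000 nM to 150000 nM.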

Compound 4, half-maximal inhibitory concentration: > 100000 nM
Compound 4 was reported as a limit (the forecaster's own chance of this, stated with the estimate: 45%); at least 3.3-fold (0.52 log units) between middle value and limit.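

In this assay compound 4 gives only a limit, > 100000 nM. With compound 3 also at a limit, no step can be read between compound 3 and compound 4. Going by these compounds, whether the methyl changes anything on the core of compound 3 stays open.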